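The source may hold more compounds than are shown below. What is called first, only, known or untested is meant among the compounds shown, and "the series" means these compounds.

Among the compounds with values here, compound 1 `CCCNC(=O)NS(=O)(=O)c1ccc(-n2nc(-c3ccccc3)ccc2=O)cc1` stands at the top of the two numbers measured so far in a functional assay on the whole organism (blood, strain Wistar albino) for inhibition, with Rattus norvegicus as the target, read by colorimetric assay, with stated times of 15 min and 90 min, at a dose of 20 mg/kg by the oral route; a higher number here means more inhibition at the dose given (going by the name of the read-out), a lower number less inhibition: compound 1 gives 77.2%. Its one measured companion, compound 2 `O=C(NC1CCCCC1)NS(=O)(=O)c1ccc(-n2nc(-c3ccccc3)ccc2=O)cc1`, carries a cyclohexyl in place of the propyl on the amide-type nitrogen, and in this assay compound 2 gives 52.1%. The step of a number 25.1 percentage points lower from compound 1 to compound 2 (beyond the scatter) lies beyond the scatter, so at that nitrogen the smaller propyl goes with more inhibition.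

Compound 3 `CCCNC(=O)NS(=O)(=O)c1ccc(-n2nc(-c3ccc(C)cc3)ccc2=O)cc1` has not yet been measured. It keeps the propyl of compound 1 and differs at a different place: methyl in place of hydrogen on an aromatic carbon

Within the data shown here, no measured step bears directly on this change. Among the measured compounds shown here, the only known step, from compound 1 to compound 2, alters the group on the amide-type nitrogen and leaves the phenyl untouched, so it gives no guidance on a methyl added to that ring. With nothing known to push the number either way, a step of a number 2.2 percentage points lower from compound 1 to compound 3 (within the scatter) that stays within the scatter is expected. Compound 3 is therefore estimated at 75%, with a range from 60% to 88%.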

Compound 3, a percentage reported as inhibition, in the whole organism at one dose (the size of the read-out at that dose, not a potency): 80.5%
The estimate for compound 3 lay 5.5 percentage points below the measured number; low and high end bracket the measured number.
By their numbers in this assay, from the lowest: compound 2; then compounds 1 and 3 (each within the scatter of the next).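

In this assay, the change from phenyl to 4-methylphenyl gives a number 3.3 percentage points higher from compound 1 to compound 3 (within the scatter), so an added methyl on this aromatic carbon, para to a large group, makes no difference that can be told apart from ordinary repeat-to-repeat variation. Within the data shown here, the only earlier step concerned the group on the amide-type nitrogen, so this pair is the first reading at the phenyl ring, and it shows that this ring position can carry a small carbon group with no detectable loss of inhibition at the dose given. No separate measurement on these compounds bears on this result.

As far as these compounds go, one methyl says little about other groups at this place, so it remains open whether a chlorine, a methoxy group, a hydroxyl group or a longer chain such as ethyl on the same aromatic carbon would give a similar number. Also open, from the compounds shown here alone, is whether the methyl would read the same alongside cyclohexyl on the amide-type nitrogen, and whether a butyl chain there would give more or less inhibition than propyl.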